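The source may report more compounds than this note shows. Statements on the series, on what has been measured and on what is new or still open speak of the compounds shown alone.

Measured so far:
- Compound 1, `CC(C)[C@H](NC(=O)CN(c1nc(Cl)nc2[nH]cnc12)C1CC1)C(=O)OCc1ccccc1`: in a functional assay on the whole organism (Tail, strain ICR) with Mus musculus as the target, in the tail flick test, with a stated time of 120 min, at a dose of 25 umol/kg by the oral route (on this read-out higher numbers stand for a stronger effect at the one dose given and lower numbers for a weaker effect), compound 1 gives 27.3%.
- Compound 2, `NCCCC[C@H](NC(=O)CN(c1nc(Cl)nc2[nH]cnc12)C1CC1)C(=O)OCc1ccccc1`: in this assay compound 2 gives 16.8%.
- Compound 3, `NCCCC[C@H](NC(=O)CN(c1nc(Cl)nc2[nH]cnc12)C1CC1)C(=O)O`: in this assay compound 3 gives 16.4%.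

From compound 2 to compound 1 the change is isopropyl in place of 4-aminobutyl on a saturated chain carbon bound to an amide-type nitrogen and a carbonyl carbon, and the step it made is a number 10.5 percentage points higher from compound 2 to compound 1 (beyond the scatter). The cores of compound 2 and compound 3 differ by hydrogen in place of benzyl on an oxygen next to a carbonyl group; the step is a number 0.4 percentage points lower from compound 2 to compound 3 (within the scatter), so the two cores read as equivalent settings on this read-out, as far as one pair can show.

Compound 4, `CC(C)[C@H](NC(=O)CN(c1nc(Cl)nc2[nH]cnc12)C1CC1)C(=O)O`, is not yet measured. From compound 3 to compound 4 the change is isopropyl in place of 4-aminobutyl on a saturated chain carbon bound to an amide-type nitrogen and a carbonyl carbon. Its place line reads word for word as in the change from compound 2 to compound 1, so this is the same change, applied on the core of compound 3 instead of that of compound 2.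

The step from compound 3 to compound 4 is expected as a number 9.6 percentage points higher from compound 3 to compound 4 (within the scatter), set beside the earlier one, resting on compound 2 to compound 1 having given a number 10.5 percentage points higher from compound 2 to compound 1 (beyond the scatter) and on the cores behaving alike in a number 0.4 percentage points lower from compound 2 to compound 3 (within the scatter). With a single earlier instance the range stays wide. Compound 4 is estimated at 26%, expected between 15% and 37%.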

Compound 4, a percentage reported as activity, at one dose (the size of the read-out at that dose, not a potency): 17.1%
For compound 4 the middle estimate is 8.9 percentage points above the measured one; low and high end bracket the measured number.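

In this assay, isopropyl in place of 4-aminobutyl gives a number 0.7 percentage points higher from compound 3 to compound 4 (within the scatter), and this step does not separate from the one seen for the same change on the core of compound 2: the same change on two cores in this assay, a number 10.5 percentage points higher (beyond the scatter) from compound 2 to compound 1 and a number 0.7 percentage points higher (within the scatter) from compound 3 to compound 4, 9.8 percentage points apart, within the scatter of two such steps. Hydrogen in place of benzyl gives a number 10.2 percentage points lower from compound 1 to compound 4 (beyond the scatter), and this step likewise does not separate from its earlier counterpart: the same change on two cores in this assay, a number 0.4 percentage points lower (within the scatter) from compound 2 to compound 3 and a number 10.2 percentage points lower (beyond the scatter) from compound 1 to compound 4, 9.8 percentage points apart, within the scatter of two such steps. The four compounds therefore show no firm dependence of either change on the core, but they do not show that either change carries over at a constant size, as each comparison rests on a single pair of steps and one step in each comparison lies within the scatter.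

Still open, from the compounds shown here alone, is how other groups on the saturated chain carbon bound to an amide-type nitrogen and a carbonyl carbon would read, such as a longer unbranched alkyl chain or a guanidine-bearing chain. Going by these compounds, it is also open whether a methyl ester or a primary amide would read with the benzyl ester or with the carboxylic acid.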